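The source may hold more compounds than are shown below. What is called first, only, known or untested is meant among the compounds shown, and "the series" means these compounds.

Compound 1 `COc1cc(OC(F)(F)F)cc(-c2ccc3c(c2)CC[C@H](CCc2nnn[nH]2)O3)c1F` was examined in a functional assay on HEK293 cells for agonist activity at Free fatty acid receptor 1 (Homo sapiens), read by HTRF and inositol phosphate accumulation, with a stated time of 60 min; on this read-out higher numbers stand for an effect only at larger amounts of compound and lower numbers for an effect already at smaller amounts. In this assay compound 1 gives > 10000 nM, which is a limit of the assay and not a number. Compound 3 `Fc1ccc(OC(F)(F)F)cc1-c1ccc2c(c1)CC[C@H](CCc1nnn[nH]1)O2` differs from compound 1 by hydrogen in place of methoxy on an aromatic carbon. In this assay compound 3 gives > 10000 nM, again a limit. The size of the step that the two limits leave unreadable from compound 1 to compound 3 cannot be read, since both values sit at the limit of > 10000 nM in this assay, at which 3 of the 3 values shown sit. Compound 2 `COc1cc(OC2CCC2)nc(-c2ccc3c(c2)CC[C@H](CCC(=O)O)O3)c1F` rests on a different core, and the difference between the two cores is not broken down here. In this assay compound 2 gives > 10000 nM, also a limit. Compound 4 `O=C(O)CC[C@H]1CCc2cc(-c3nc(OC4CCC4)ccc3F)ccc2O1` has not yet been measured; it differs from compound 2 by hydrogen in place of methoxy on an aromatic carbon. This is the same kind of change as that from compound 1 to compound 3, though here the six-membered aromatic ring holds one nitrogen, the site lies opposite the ring nitrogen and meta to a cyclobutyloxy group rather than a trifluoromethoxy group. The step is expected to be a step that the limit leaves unreadable from compound 2 to compound 4, resting on the unreadable step that the two limits leave unreadable from compound 1 to compound 3 and on compound 2 sitting at a limit. Compound 4 is thus expected to give about 15000 nM, between 4000 nM and 60000 nM.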

Compound 4, half-maximal effective concentration: > 10000 nM
Compound 4 was reported as a limit; the forecaster's own chance of this, stated with the estimate: 80%; the middle value is on the limit's open side.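

In this assay compound 4 gives > 10000 nM, which is a limit of the assay and not a number, so no size can be read for the step from compound 2 to compound 4: the limit of > 10000 nM in this assay, at which 4 of the 4 values shown sit. The compounds shown leave open whether hydrogen in place of methoxy on an aromatic carbon changes agonist activity at all.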